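The source may hold more compounds than are shown below. What is called first, only, known or untested is meant among the compounds shown, and "the series" means these compounds.

Two compounds have been measured in a physicochemical assay for lipophilicity, read by LC-MS; a lower number here means a more polar compound, a higher number a more lipophilic compound:

compound 1 (`FC(F)(F)c1nccc(N[C@H]2CC[C@@H](Nc3ccc4ncc(Cl)n4n3)CC2)n1`): 4.3
compound 2 (`Clc1nnc2ccc(N[C@H]3CC[C@@H](Nc4ccncn4)CC3)nn12`): 0.7

Compound 2 holds the lower of these two numbers, and the gap up to compound 1 lies well beyond the scatter of repeated measurements. The next compound, compound 3 (`COc1ncc(N[C@H]2CC[C@@H](Nc3ccc4nnc(Cl)n4n3)CC2)cc1Cl`), keeps the core of compound 2 and changes one group: 5-chloro-6-methoxypyridin-3-yl in place of pyrimidin-4-yl on an amine nitrogen. Thus 5-chloro-6-methoxypyridin-3-yl stands in place of pyrimidin-4-yl on an amine nitrogen.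

Going by the values given here, no measured pair isolates a change of this kind, so the data give no direct guide to its size. The only frame is the span from compound 2 at 0.7 to compound 1 at 4.3, and those two compounds differ in more than one place. Resting on the structural change itself, an upward move in this assay beyond the scatter is expected, ending inside that span. The expected move, an estimate only, is a number 2.00 log units higher from compound 2 to compound 3 (beyond the scatter). Compound 3 is estimated at 2.7, with an expected range from 2 to 3.4.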

Compound 3, distribution coefficient: 3.8
Beside the measured number, compound 3's estimate is 1.10 log units below it; the measured number lies above the stated range.
By their numbers in this assay, from the lowest: compound 2; then compound 3; then compound 1.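

With the core held fixed, this assay now gives a measured size for a change at this position: 5-chloro-6-methoxypyridin-3-yl in place of pyrimidin-4-yl on an amine nitrogen is a number 3.10 log units higher from compound 2 to compound 3 (beyond the scatter) and is a large step. Going by these compounds alone, this is the first step that isolates one place, and it shows that the group on this amine nitrogen, whose other neighbour is a saturated ring carbon, can by itself move the read-out by a wide margin, which compound 1 and compound 2 could not show, as they differ in more than one place. No measurement at hand bears on what lies behind this step.

Going by these compounds, the exchange alters the ring, the chlorine and the methoxy group in one move, so how the step divides among them remains open. Also open, on these data alone, is whether a pyridin-3-yl ring with only the chlorine or only the methoxy group, or a ring bearing an amine or a carboxylic acid, would read closer to compound 2 or to compound 3, and whether the same exchange would give a step of similar size on the core of compound 1.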